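A few compounds are considered here, and "the series" means these few. Any claim that something is new, unique, unknown or untested is made for them only; others in the source may bear on it.

Working notes on the aryl urea series.

Three compounds of this series carry a measurement in a functional assay on B16-F10 cells (Mus musculus) for cytotoxicity, read by MTT assay, with a stated time of 48 h; a lower number here means a stronger inhibitor, a higher number a weaker inhibitor. Compound 1 `COc1ccc(CN(C(=O)Nc2ccc(Cl)cc2)n2cnnc2)cc1OC` gives 42200 nM and stands highest of the three. Compound 3 `COc1ccc(OC)c(CN(C(=O)Nc2ccc(C)cc2)n2cnnc2)c1`, which carries a methylphenyl urea on a differently substituted core, gives 20700 nM, a lower number beyond the scatter. Compound 2 `COc1cc(CN(C(=O)Nc2cc(C(F)(F)F)cc(C(F)(F)F)c2)n2cnnc2)cc(OC)c1OC`, the bis(trifluoromethyl)phenyl urea, gives 5620 nM, the lowest number of the three and well beyond the scatter from compound 1.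

Compound 4 `COc1ccc(CN(C(=O)Nc2ccc(C)cc2)n2cnnc2)cc1OC` is not yet measured. It keeps the core of compound 1 and changes only the urea aryl: methyl in place of chloro on an aromatic carbon. Within the data shown here, no pair differing only in this change has been measured, so the size of the step is open. Compound 3 shows that a methylphenyl urea can sit at a lower number than compound 1, but its core differs, so nothing firm follows for compound 4.

The step of a 1.4-fold lower number from compound 1 to compound 4 (0.15 log units; within the scatter) is expected to be small, toward a lower number, and possibly not beyond the scatter. Compound 4 is estimated at 30000 nM, within a range from 12000 nM to 75000 nM.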

Compound 4, half-maximal inhibitory concentration: 29900 nM
Compound 4: the middle estimate sits 1.0-fold (0.00 log units) above what was measured; the measured number falls inside the stated range.
By their numbers in this assay, from the lowest: compound 2; then compounds 3, 4 and 1 (each within the scatter of the next, the first and the last beyond it).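

In this assay, among these compounds, the exchange of chloro for methyl gives a 1.4-fold lower number from compound 1 to compound 4 (0.15 log units; within the scatter) on the shared core, the first step that can be read for a single change. Among the compounds shown here, at this place, on an aromatic carbon para to a large group, going from 4-chlorophenyl to 4-methylphenyl therefore does not separate the two compounds beyond the scatter, which the earlier compounds, differing in more than one place, could not show. No evidence at hand bears on this result.

Going by these compounds, whether an amine, a carboxylic acid or a longer chain on this carbon would give a step beyond the scatter stays open. Also open, on these data alone, is whether methyl in place of chloro gives a step of similar size on other cores.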